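The source may report more compounds than this note shows. Statements on the series, on what has been measured and on what is new or still open speak of the compounds shown alone.

Measured so far:
Compound 1 `COc1ccc(-c2cn(Cc3ccc(F)cc3)c(=O)c(C(=O)NC3CCCCCC3)c2-c2ccccc2)cc1` gives > 10000 nM in an ADME assay on cells for inhibition of Fatty-acid amide hydrolase 1 (Homo sapiens), with stated times of 30 min and 15 min (on this read-out lower numbers stand for stronger inhibition and higher numbers for weaker inhibition), which is a limit of the assay rather than a number.
Compound 2 `O=C(NC1CCCCCC1)c1c(-c2ccccc2)ccn(Cc2ccc(F)cc2)c1=O` gives > 10000 nM in this assay, again a limit.
Compound 3 `Cc1c(-c2ccccc2)cn(Cc2ccc(F)cc2)c(=O)c1C(=O)NC1CCCCCC1` gives 70 nM in this assay.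

Compound 3 is therefore the only one of the three with a measured number; the other two sit at a limit, and nothing can be said about their order. The step followed here leads to compound 4 `O=C(NC1CCCCCC1)c1c(-c2ccccc2)c(-c2ccccc2)cn(Cc2ccc(F)cc2)c1=O`, not yet measured. The change is phenyl in place of methyl on an aromatic carbon.

For the measured compounds named here, only one measured step touches the same position: from compound 1 to compound 2, a step that the two limits leave unreadable from compound 1 to compound 2, so its size is not readable. The values themselves show a pattern of sorts: with methyl at this position compound 3 gives a number, whereas with a larger 4-methoxyphenyl compound 1 sits at the limit. Compound 2, with hydrogen there, sits at the limit as well. Phenyl, being an aromatic ring like 4-methoxyphenyl, is expected to behave more like compound 1 than like compound 3, which is the reasoning behind the expected step of a 110-fold higher number from compound 3 to compound 4 (2.06 log units; beyond the scatter), pointing toward weaker inhibition.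

Compound 4 is thus estimated at 8000 nM, within a range of 1000 nM to 40000 nM, with a good chance that only a limit is reported.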

Compound 4, half-maximal inhibitory concentration: > 10000 nM
Compound 4: only a limit was reported (the forecaster's own chance of this, stated with the estimate: 55%); at least 1.2-fold (0.09 log units) between middle value and limit.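

For the compounds shown here, this is the first readable step at this position, the carbon ortho to the cycloheptylcarbamoyl group: in this assay, phenyl in place of methyl gives an at least 140-fold higher number from compound 3 to compound 4 (2.15 log units; beyond the scatter), so this single change is enough to lose nearly all measurable inhibition. Compounds 1, 2 and 4 all carry phenyl on this carbon and differ only at the other ring carbon that varies, where they hold 4-methoxyphenyl, hydrogen and phenyl; the steps linking compound 4 to compounds 1 and 2 cannot be read, since both ends of each are limits. Among the compounds shown, then, a number appears only with methyl on this carbon, and compound 3 is the sole example, so the pattern rests on one compound.

As far as these compounds go, whether ethyl, cyclopropyl, an amine or a chlorine atom on this carbon would keep the inhibition remains open, as does whether methyl here still gives a number when the neighbouring phenyl of compound 3 is replaced by hydrogen or 4-methoxyphenyl. How far compounds 1, 2 and 4 lie past the limit also stays unknown: the limit of > 10000 nM in this assay, at which 3 of the 4 values shown sit.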